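The compounds below may be only part of what the source reports. "The series", "measured", "known", "first", "only" and "open" are said of these compounds alone.

Measured so far:
compound 1 `CCCc1csc(CN[C@@H]2C[C@H]3C[C@@H]([C@H]2C)C3(C)C)c1` — 12500 nM
compound 2 `Cc1csc(CN[C@@H]2C[C@H]3C[C@@H]([C@H]2C)C3(C)C)c1` — 12500 nM

In an ADME assay on MDCK cells (Canis lupus familiaris) for cytotoxicity, read by microscopy, with a stated time of 48 h (on this read-out higher numbers stand for lower toxicity in this test and lower numbers for higher toxicity in this test), compound 1 gives 12500 nM, and in this assay compound 2 gives 12500 nM. Compound 2 stands level with compound 1 at the digits shown; the single measured step, no change at the digits printed from compound 1 to compound 2 (within the scatter), lies within the scatter, so the length of the saturated chain on the aromatic carbon did not move the minimum cytotoxic concentration here.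

Compound 3 `C[C@H]1[C@H](NCc2cc(-c3ccsc3)cs2)C[C@H]2C[C@@H]1C2(C)C` is not yet measured. It differs from compound 2 by thiophen-3-yl in place of methyl on an aromatic carbon. Among the measured compounds shown here, the only measured step touches the same aromatic carbon but swaps one saturated chain for a shorter one; it does not bring a second aromatic ring into the molecule, so it bears on the present change only loosely. For the measured compounds named here, nothing in the two measured compounds shows this read-out moving at all, and no step with an aromatic group entering is available. Going by the values given here, on that footing compound 3 is expected to sit near compound 2, with the step of a 1.3-fold lower number from compound 2 to compound 3 (0.10 log units; within the scatter) expected to stay within the scatter, though with a wide range because no comparable step was measured. For compound 3 the estimate in this assay is 10000 nM, from 3000 nM to 25000 nM.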

Compound 3, minimum cytotoxic concentration: 25000 nM
Beside the measured number, compound 3's estimate is 2.5-fold (0.40 log units) below it, and the stated range covers the measured number.
By their numbers in this assay, from the lowest: compounds 1, 2 and 3 (each within the scatter of the next).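

In this assay, thiophen-3-yl in place of methyl on the aromatic carbon gives a 2.0-fold higher number from compound 2 to compound 3 (0.30 log units; within the scatter), and thiophen-3-yl in place of propyl on the same carbon gives a 2.0-fold higher number from compound 1 to compound 3 (0.30 log units; within the scatter). The earlier pair covered only saturated chains at this position, two ring bonds from the ring sulfur; these steps extend the observation to a five-membered aromatic ring with 1 sulfur, and across the three groups shown, no step lies beyond the scatter of this read-out. No supporting data are available to explain this result.

Going by these compounds, whether a carboxylic acid, an amine or a phenyl ring on this aromatic carbon would also stay within the scatter remains open, as does the behaviour of a longer chain. On these data alone, all three compounds share one core, so the response of the minimum cytotoxic concentration to a change in the core, or to a thiophen-3-yl group at another ring position, also remains open.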